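This account rests on a few compounds, and the source may have more. Where it says the series, first, only, none or still open, it means among the compounds named here.

Measured so far:
compound 1, `CC1(c2ccccc2)CC(=O)N(CC(=O)N2CCN(c3ccccc3Cl)CC2)C1=O`: 100 mg/kg
compound 2, `CC1(c2ccccc2)CC(=O)N(CC(=O)N2CCN(c3ccc(F)cc3)CC2)C1=O`: "not active" (no number reported)
compound 3, `CC1(c2ccccc2)CC(=O)N(CC(=O)N2CCN(c3cccc(Cl)c3)CC2)C1=O`: "not active" (no number reported)

Among the compounds with values here, in a functional assay on the whole organism (strain CD-1) with Mus musculus as the target, with a stated time of 2 h (a higher number here means that more compound is needed for the effect, a lower number that less compound is needed), compound 1 gives 100 mg/kg, the only number obtained among the three. Compound 2 is reported in this assay as "not active" (no number reported), without a number. Compound 3 is likewise reported in this assay as "not active" (no number reported), without a number. Within the data shown here, compound 1 therefore stands alone as the measured compound with a stated dose, and no step between two measured compounds is known, so how much this part of the molecule matters cannot be read from the data. Compound 4, `CC1(c2ccccc2)CC(=O)N(CC(=O)N2CCN(c3ccccc3F)CC2)C1=O`, is not yet measured. It differs from compound 1 in one place: fluoro in place of chloro on an aromatic carbon. The place of the group is kept; only its identity changes. Among the measured compounds shown here, because compound 1 gives 100 mg/kg and no measured step guides the size, the expected step is small, toward a higher dose, a 2.0-fold higher number from compound 1 to compound 4 (0.30 log units; within the scatter), with a real chance that no number is obtained. Compound 4 is expected to need 200 mg/kg in this assay, within 80 mg/kg to 600 mg/kg.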

Compound 4, minimum effective dose: 300 mg/kg
Compound 4: middle estimate off by 1.5-fold (0.18 log units), on the low side; measured number inside the range.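

In this assay, within the data shown here, the exchange of 2-chlorophenyl for 2-fluorophenyl gives a 3.0-fold higher number from compound 1 to compound 4 (0.48 log units; beyond the scatter) and so puts the first size on a change at this place on the aromatic ring. Among these compounds, the identity of the group here does matter, though modestly, and chloro is not the only group at this place that yields a stated dose. Nothing shown explains why the required dose shifts with this exchange.

The compounds shown leave open whether a group other than a halogen, such as methyl or methoxy, would keep a stated dose at this place, and how a bromo group or a plain phenyl with no group would compare. They also leave open how much the shared core contributes, since every compound here keeps it unchanged.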